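Changing the aromatic nitrogen group of compound 2

The source may hold more compounds than are shown below. What is called first, only, known or untested is meant among the compounds shown, and "the series" means these compounds.

Values so far in a functional assay on A549 cells (Homo sapiens) for cytotoxicity, read by MTT assay, with a stated time of 72 h; a higher number here means a weaker inhibitor, a lower number a stronger inhibitor:
Compound 1 `CNC(=O)c1cc(Oc2ccc(NC(=O)c3nn(-c4ccccc4C(F)(F)F)c(=O)cc3C)cc2F)ccn1` gives > 40000 nM as a limit of the assay, not a number
Compound 2 `Cc1cc(=O)n(-c2ccccc2C(F)(F)F)nc1C(=O)Nc1ccc(Oc2ncnc3ccsc23)c(F)c1` gives 4680 nM as a measured number

Among the compounds with values here, compound 2 holds the only true number in this assay and is the reference for what follows. Within the data shown here, the one measured step, an at least 8.5-fold lower number from compound 1 to compound 2 (0.93 log units; beyond the scatter), exchanges the group on the oxygen and lies beyond the scatter. That step leaves the group on the aromatic nitrogen untouched, so it bears on the present change only indirectly.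

Compound 3 `Cc1cc(=O)n(-c2ccc(F)cc2)nc1C(=O)Nc1ccc(Oc2ncnc3ccsc23)c(F)c1` keeps the group on the oxygen found in compound 2 and changes the other end: 4-fluorophenyl in place of 2-(trifluoromethyl)phenyl on an aromatic nitrogen. Among the measured compounds shown here, no measured step covers this place, so neither direction is favoured and the expectation stays anchored on compound 2 at 4680 nM as its starting point. The expected change is a 1.1-fold higher number from compound 2 to compound 3 (0.03 log units; within the scatter) and no step beyond the scatter is predicted, though with wide uncertainty. The estimate for compound 3 is 5000 nM with an expected range from 1500 nM to 18000 nM in this series.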

Compound 3, half-maximal inhibitory concentration: 580 nM
Compound 3: the middle estimate sits 8.6-fold (0.94 log units) above what was measured; the measured number lies below the stated range.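

In this assay, the group on the aromatic nitrogen turns out to matter: 4-fluorophenyl in place of 2-(trifluoromethyl)phenyl gives an 8.1-fold lower number from compound 2 to compound 3 (0.91 log units; beyond the scatter). Within the data shown here, until now the only measured step lay at the group on the oxygen, so the series now shows a step beyond the scatter at each of the two places changed, with the core kept constant. Compound 1 is the only compound at a limit of the assay, not a number, whereas the new step joins two true numbers: the limit of > 40000 nM in this assay, at which 1 of the 3 values shown sits.

The change removes a trifluoromethyl group and adds a fluorine in one move, so the compounds shown do not tell whether the loss of the one or the arrival of the other carries the step, and they give no cause for it. Open too, going by these compounds, is how an unsubstituted phenyl, a 2-fluorophenyl or a cyclohexyl group on the aromatic nitrogen would read, and whether 4-fluorophenyl gives a similar step with the group on the oxygen found in compound 1.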